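The compounds below may be only part of what the source reports. "The series", "measured", "known", "first", "only" and "open" are said of these compounds alone.

Measured compounds:
compound 1, `O=C(Nc1ccc2[nH]c(=O)oc2c1)C(=O)N1CCN(c2ccc(Cl)cc2)CC1`, 17.8%
compound 2, `O=C(Nc1ccc2[nH]c(=O)oc2c1)C(=O)N1CCN(c2ccc(F)cc2)CC1`, 39.3%
compound 3, `C[C@@H]1CN(c2ccc(F)c(F)c2)CCN1C(=O)C(=O)Nc1ccc2[nH]c(=O)oc2c1`, 118%

The three compounds were tested in an ADME assay on the whole organism (Rattus norvegicus, strain Sprague-Dawley) for pharmacokinetics, using cassette dosing, at a dose of 1 mg/kg by the oral route; a lower number here means that a smaller share of the oral dose reaches the circulation, a higher number that a larger share of the oral dose reaches the circulation. The first two share a core and differ in one place: chloro in place of fluoro on an aromatic carbon. That change gives a number 21.5 percentage points lower from compound 2 to compound 1 (beyond the scatter). Compound 3 carries a different core; how its core differs from that of compound 2 is not broken down here. In this assay compound 3 gives the highest of the three numbers, and its distance to compound 2 and to compound 1 is beyond the scatter in each case.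

Compound 4, `C[C@@H]1CN(c2ccc(Cl)c(F)c2)CCN1C(=O)C(=O)Nc1ccc2[nH]c(=O)oc2c1`, has not yet been measured. It differs from compound 3 by chloro in place of fluoro on an aromatic carbon. Among the measured compounds shown here, this is the same kind of change as the one from compound 2 to compound 1, but not the same: in compound 4 the changed carbon is ortho to a fluoro group as well as para to a large group, whereas in compound 1 it is para to a large group only.

Resting on the step of a number 21.5 percentage points lower from compound 2 to compound 1 (beyond the scatter), a step of similar direction is expected from compound 3 to compound 4, namely a number 26 percentage points lower from compound 3 to compound 4 (beyond the scatter). For the measured compounds named here, compound 4 is thus estimated at 92% in this assay, with a range from 55% to 125%, the range being wide since only one earlier example of this change exists and its surroundings differ.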

Compound 4, oral bioavailability: 30.4%
Compound 4: the middle estimate sits 61.6 percentage points above what was measured; the measured number lies below the stated range.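

In this assay, chloro in place of fluoro on an aromatic carbon gives a number 87.6 percentage points lower from compound 3 to compound 4 (beyond the scatter), a large step. Set beside the earlier example, the change points the same way on both cores but does not carry over in size from one to the other: the same change on two cores in this assay, a number 21.5 percentage points lower (beyond the scatter) from compound 2 to compound 1 and a number 87.6 percentage points lower (beyond the scatter) from compound 3 to compound 4, 66.1 percentage points apart, beyond the scatter of two such steps What this does not show is where the difference comes from, since the two pairs differ in their cores and also in their surroundings on the aromatic ring, where the changed carbon in compound 4 is ortho to a fluoro group and the one in compound 1 is not, and two pairs cannot separate these.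

The compounds shown leave open what the change from 3,4-difluorophenyl to 4-chloro-3-fluorophenyl would give on the core of compound 1, which would set the core apart from the neighbouring fluoro group as the place where the size of the step is decided. They also leave open how a bromo, methyl, nitrile or trifluoromethyl group in the place of the chloro would read on either core, so the series says nothing yet about groups other than these two halogens at this carbon.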